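The source may hold more compounds than are shown below. What is called first, only, known or untested is meant among the compounds shown, and "the series" means these compounds.

Measured compounds:
compound 1, `CC1CCN(c2c(S(=O)(=O)c3ccccc3)cnc3ccc(Cl)cc23)CC1`, 59%
compound 2, `COc1cccc(S(=O)(=O)c2cnc3ccc(Cl)cc3c2N2CCC(C)CC2)c1`, 87%
compound 3, `COc1ccc(S(=O)(=O)c2cnc3c(F)cccc3c2N2CCC(C)CC2)cc1`, 67%

The three measured compounds were tested in an assay on isolated protein for displacement of a labelled ligand from metabotropic glutamate receptor 5 (Homo sapiens), with a stated time of 60 min, tested at 1 uM; a higher number here means more inhibition at the concentration tested (going by the name of the read-out), a lower number less inhibition. Going by the values given here, compound 2 gives the highest number of the three, and the step from compound 2 to compound 1, a number 28 percentage points lower from compound 2 to compound 1 (beyond the scatter), is the one counted change that exists between measured compounds here: hydrogen in place of methoxy on an aromatic carbon. Compound 3 stands between the two, and its gap to compound 1 lies within the scatter. How the core of compound 3 differs from that of compound 2 is not broken down here.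

Compound 4, `CC1CCN(c2c(S(=O)(=O)c3ccccc3)cnc3c(F)cccc23)CC1`, has not yet been measured. It differs from compound 3 by hydrogen in place of methoxy on an aromatic carbon. Among the compounds with values here, this is the same kind of change as the one from compound 2 to compound 1, though the group removed sits para to a large group in compound 3 and meta to a large group in compound 2, so the two are not the same change.

Because the step of a number 28 percentage points lower from compound 2 to compound 1 (beyond the scatter) was modest and beyond the scatter, a step of similar direction is expected for compound 4, namely a number 27 percentage points lower from compound 3 to compound 4 (beyond the scatter). Compound 4 is therefore estimated at 40%. The expected range for compound 4 runs from 22% to 58%.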

Compound 4, a percentage reported as inhibition, at one concentration (the size of the read-out at that concentration, not a potency): 13%
Compound 4: the middle estimate sits 27 percentage points above what was measured; measured number below the stated range.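

In this assay, replacing the methoxy group with hydrogen again lowers the number, with a number 54 percentage points lower from compound 3 to compound 4 (beyond the scatter) as the new step. The direction of the change carries over from one core to the other, but its size does not: the same change on two cores in this assay, a number 28 percentage points lower (beyond the scatter) from compound 2 to compound 1 and a number 54 percentage points lower (beyond the scatter) from compound 3 to compound 4, 26 percentage points apart, beyond the scatter of two such steps

The two pairs differ both in the core and in where the methoxy group stands, para to a large group in compound 3 and elsewhere on the ring in compound 2, so they cannot show which of these two differences goes with the larger step, and two pairs set no rule for the wider series.

The compounds shown leave open whether a methoxy group placed as in compound 2 would behave on the core of compound 3 as it does in compound 3 itself. They also leave open whether an ethoxy group, a hydroxyl group or a chlorine atom in the place of the methoxy group would hold the number up as methoxy does.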